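The compounds below may be only part of what the source reports. "The series", "measured", "known", "first", "only" and "open" are said of these compounds alone.

Of the compounds shown here, three share one core and have been measured in a functional assay on HepG2 cells (Homo sapiens) for antiproliferative activity, read by MTT assay, with a stated time of 72 h; a higher number here means a weaker inhibitor, a lower number a stronger inhibitor. Compound 1 `C=C(Cl)C(=O)Nc1cc(Nc2nccc(-c3cn(C)c4ccccc34)n2)c(OC)cc1N(C)CCN(C)C` gives 1390 nM. Compound 2 `COc1cc(N(C)CCN(C)C)c(NC(=O)C=C(C)C)cc1Nc1nccc(-c2cn(C)c3ccccc23)n1` gives 5660 nM; the change of a 4.1-fold higher number from compound 1 to compound 2 (0.61 log units; beyond the scatter) reads as a weakening. Compound 3 `C=C(Cl)C(=O)Nc1cc(Nc2ncc(C#N)c(-c3cn(C)c4ccccc34)n2)c(OC)cc1N(C)CCN(C)C` gives 115 nM, and the step of a 12-fold lower number from compound 1 to compound 3 (1.08 log units; beyond the scatter) is the largest shift among the three. Compound 3 therefore stands with the lowest number of the three, and its nearest neighbour is compound 1.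

Compound 4 `CCC/C=C\C(=O)Nc1cc(Nc2ncc(C#N)c(-c3cn(C)c4ccccc34)n2)c(OC)cc1N(C)CCN(C)C` is not yet measured. It differs from compound 3 in one place: pent-1-en-1-yl in place of 1-chloroethenyl on a carbonyl carbon. Among the compounds with values here, the step that bears most closely on this change is the one from compound 1 to compound 2, where the 1-chloroethenyl group was likewise exchanged for a substituted alkenyl group and gave a 4.1-fold higher number from compound 1 to compound 2 (0.61 log units; beyond the scatter). On that basis a modest weakening beyond the scatter is expected, in the same direction, in this assay.

Compound 4 is thus estimated at 400 nM, within a range from 150 nM to 1200 nM. The expected step is a 3.5-fold higher number from compound 3 to compound 4 (0.54 log units; beyond the scatter).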

Compound 4, half-maximal inhibitory concentration: 1690 nM
For compound 4 the middle estimate is 4.2-fold (0.63 log units) below the measured one; measured number outside the range, above it.
By their numbers in this assay, from the lowest: compound 3; then compounds 1 and 4 (each within the scatter of the next); then compound 2.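

Exchanging 1-chloroethenyl for pent-1-en-1-yl on the carbonyl carbon gives a 15-fold higher number from compound 3 to compound 4 (1.17 log units; beyond the scatter), so this position still matters on the core that carries the cyano group. Until now, an exchange at this position had been seen only on the core without that group, where it gave a 4.1-fold higher number from compound 1 to compound 2 (0.61 log units; beyond the scatter); the two listed exchanges at this position, one on each core, both raise the number, and neither compound pair goes against that direction. No measurement shown here accounts for the size of the new step.

The compounds leave open whether the loss follows from removing the chlorine or from adding the longer chain. A plain ethenyl group or a prop-1-en-1-yl group on the same carbonyl carbon of the cyano-bearing core would help separate the two.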